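Aryl ether to saturated ring: permeability notes

A few compounds are considered here, and "the series" means these few. Any claim that something is new, unique, unknown or untested is made for them only; others in the source may bear on it.

Measured values in an ADME assay for permeability, using PAMPA, with a stated time of 30 min, at pH 7.4; on this read-out lower numbers stand for lower permeability and higher numbers for higher permeability:
- compound 1, `COc1ccccc1Oc1ccc2c(NCCCNCc3ccco3)ccnc2c1`: 317 10^-6 cm/s
- compound 2, `COc1ccc(Oc2ccc3c(NCCCNCc4cc(F)ccc4OC)ccnc3c2)cc1`: 317 10^-6 cm/s
- compound 3, `CC(C)Cc1ccc2c(NCCCNCc3ccco3)ccnc2c1`: 23 10^-6 cm/s

Compound 2 stands level with compound 1 at the digits recorded, the two together being the highest of the three numbers in this assay; compound 3 is the furthest from it, at a lower value. The next compound, compound 4 `COc1ccc(F)cc1CNCCCNc1ccnc2cc(C3CCCCC3)ccc12`, differs from compound 2 in one place: cyclohexyl in place of 4-methoxyphenoxy on an aromatic carbon.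

For the measured compounds named here, one measured step bears on this change. The replacement of the aryl ether by a saturated carbon group was a 14-fold lower number from compound 1 to compound 3 (1.14 log units; beyond the scatter), a large drop. The change from compound 2 to compound 4 is of the same kind, so a step of comparable size downward in this assay is expected, beyond the scatter. Compound 4 is therefore estimated at 30 10^-6 cm/s, in the range 10 10^-6 cm/s to 100 10^-6 cm/s, which corresponds to the expected step of an 11-fold lower number from compound 2 to compound 4 (1.02 log units; beyond the scatter).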

Compound 4, apparent permeability: 23 10^-6 cm/s
The estimate for compound 4 lay 1.3-fold (0.12 log units) above the measured number, within the range that was stated.
By their numbers in this assay, from the lowest: compounds 3 and 4 (each within the scatter of the next); then compounds 1 and 2 (each within the scatter of the next).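

The fall in this assay seen as a 14-fold lower number from compound 1 to compound 3 (1.14 log units; beyond the scatter) recurs as a 14-fold lower number from compound 2 to compound 4 (1.14 log units; beyond the scatter) in a second pair, so at this aromatic carbon it is not confined to one aryl ether or to one entering group. Cyclohexyl keeps a six-membered ring at this place, non-aromatic where the ring of 4-methoxyphenoxy is aromatic, and the step is still as large as the one with isobutyl at the digits printed. Nothing on hand gives a measured reason for either step.

From the compounds shown here alone, whether the step follows the ether oxygen or the aromatic ring stays open: a phenyl group joined directly to this carbon would separate the two. Going by these compounds, how a cyclohexyl ring carrying an amine or a carboxylic acid would read at this place is also open.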